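Working notes: shortening the side chain of compound 2

The source may hold more compounds than are shown below. What is called first, only, known or untested is meant among the compounds shown, and "the series" means these compounds.

Measured in an ADME assay on S9 fraction from liver (Rattus norvegicus) for metabolic stability, read by LC-MS, using NADPH, with a stated time of 60 min, tested at 10 uM; a lower number here means that less of the compound is left, a higher number that more of the compound is left:
compound 1 `C[C@@H](O)Cc1cc(-c2ccnc3[nH]nc(C(F)(F)F)c23)cc(C2(C#N)CC2)c1`: 42%
compound 2 `COCC(O)Cc1cc(-c2ccnc3[nH]nc(C(F)(F)F)c23)cc(C2(C#N)CC2)c1`: 51%

Among the measured compounds shown here, compound 2 stands within the scatter of compound 1, the only other measured number. The next structure is compound 3 `COCCc1cc(-c2ccnc3[nH]nc(C(F)(F)F)c23)cc(C2(C#N)CC2)c1`, and the change from compound 2 is methoxymethyl in place of 1-hydroxy-2-methoxyethyl on a saturated chain carbon bound to an aromatic carbon. Cut one bond further out, the same change reads 2-hydroxy-3-methoxypropyl to 2-methoxyethyl.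

For the measured compounds named here, only one measured step alters this chain: a number 9 percentage points higher from compound 1 to compound 2 (within the scatter). Going by the values given here, it keeps the hydroxy group, so it bears on the new change only indirectly, and no measured step removes that group. On this thin evidence, no shift beyond the scatter is expected in this assay, with a slight lean downward. The expected change is a number 8 percentage points lower from compound 2 to compound 3 (within the scatter). The estimate for compound 3 is 43%, with an expected range of 25% to 62%.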

Compound 3, percent of the compound remaining: 90%
Compound 3: the middle estimate sits 47 percentage points below what was measured; the measured number lies above the stated range.
By their numbers in this assay, from the lowest: compounds 1 and 2 (each within the scatter of the next); then compound 3.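

In this assay, among the compounds shown here, this position proves far from indifferent to the chain it carries: a number 39 percentage points higher from compound 2 to compound 3 (beyond the scatter) and a number 48 percentage points higher from compound 1 to compound 3 (beyond the scatter) while the only earlier step, between the two chains that keep a hydroxy group, stayed within the scatter. Among these compounds, the 2-methoxyethyl chain of compound 3, the one chain with no hydrogen-bond donor, stands apart from both hydroxy-bearing chains, and none of the three goes against that split. Nothing available here explains the size of this change.

The change removes the hydroxy group and shortens the chain in a single step, so the data leave open which of the two carries the rise. Also open, from the compounds shown here alone, is whether a longer ether such as 3-methoxypropyl, or an amine on the same saturated chain carbon, would keep the number of compound 3 in this assay.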